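A few compounds are considered here, and "the series" means these few. Any claim that something is new, unique, unknown or untested is made for them only; others in the source may bear on it.

In a functional assay on HL-60 cells (Homo sapiens) for cytotoxicity, read by ELISA, with a stated time of 2 days (a lower number here means a stronger inhibitor, a higher number a weaker inhibitor), compound 1 (`Oc1cccc(-c2cc(-c3ccccc3)nc(-c3cccs3)c2)c1`) gives 18900 nM and compound 2 (`Oc1cccc(-c2cc(-c3ccccc3)nc(-c3ccncc3)c2)c1`) gives 12700 nM. Compound 2 therefore stands within the scatter of compound 1, with a 1.5-fold lower number from compound 1 to compound 2 (0.17 log units; within the scatter). Compound 3 (`Oc1ccc(-c2cc(-c3ccccc3)nc(-c3ccncc3)c2)cc1`) carries 4-hydroxyphenyl in place of 3-hydroxyphenyl on an aromatic carbon. Among the measured compounds shown here, the one measured step, a 1.5-fold lower number from compound 1 to compound 2 (0.17 log units; within the scatter), lies at another place on the shared core, so it bears only loosely on this change, and no shift beyond the scatter is expected in this assay. The expected step is a 1.1-fold lower number from compound 2 to compound 3 (0.02 log units; within the scatter). For compound 3 the estimated value is 12000 nM, with an expected range from 4500 nM to 32000 nM.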

Compound 3, half-maximal inhibitory concentration: 1400 nM
Estimate against measurement, compound 3: 8.6-fold (0.93 log units) above; measured number below the stated range.
By their numbers in this assay, from the lowest: compound 3; then compounds 2 and 1 (each within the scatter of the next).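

In this assay, among the compounds shown here, 4-hydroxyphenyl in place of 3-hydroxyphenyl gives a 9.1-fold lower number from compound 2 to compound 3 (0.96 log units; beyond the scatter) and is the only step here beyond the scatter. The two groups have the same atoms joined differently, so this position responds to where the hydroxyl sits on the phenyl ring, which the earlier change at another place on the shared core could not show. No available evidence bears on why this step is so large. Open, from the compounds shown here alone, is whether a methoxy or an amine in place of that hydroxyl would keep the lower number. Also open, going by these compounds, is whether 4-hydroxyphenyl would give a similar step with thiophen-2-yl in place of pyridin-4-yl.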